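A few compounds are considered here, and "the series" means these few. Any claim that something is new, unique, unknown or untested is made for them only; others in the source may bear on it.

Among the compounds with values here, compound 2 `Cc1cc(Sc2ccccc2)c(S(C)(=O)=O)cc1C(=O)N=C(N)N` gives the lowest of the two numbers so far: in a functional assay for inhibition of sodium/hydrogen exchanger (Oryctolagus cuniculus) (on this read-out lower numbers stand for stronger inhibition and higher numbers for weaker inhibition), compound 2 gives 14 nM, while compound 1 `Cc1cc(-c2ccc(Cl)cc2Cl)c(S(C)(=O)=O)cc1C(=O)N=C(N)N` gives 42 nM. Within the data shown here, the only measured step, a 3.0-fold lower number from compound 1 to compound 2 (0.48 log units; beyond the scatter), swaps one ring-bearing group for another. Compound 3 `Cc1cc(OC(C)C)c(S(C)(=O)=O)cc1C(=O)N=C(N)N` instead carries isopropoxy in place of phenylsulfanyl on an aromatic carbon. Among the measured compounds shown here, no measured step covers an alkoxy group in this place, so the one known step offers little guidance. The expected change from compound 2 to compound 3 in this assay is a 2.1-fold higher number from compound 2 to compound 3 (0.33 log units; beyond the scatter), a small shift toward a weaker value. Compound 3 is therefore estimated at 30 nM, within a range of 8 nM to 110 nM.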

Compound 3, half-maximal inhibitory concentration: 19 nM
The estimate for compound 3 lay 1.6-fold (0.20 log units) above the measured number; the measured number falls inside the stated range.
By their numbers in this assay, from the lowest: compounds 2 and 3 (each within the scatter of the next); then compound 1.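

In this assay, an aromatic ring at this position proves unnecessary for a low number: a 1.4-fold higher number from compound 2 to compound 3 (0.13 log units; within the scatter) when ring-free isopropoxy replaces phenylsulfanyl, so the two compounds cannot be told apart. The same isopropoxy group also compares well with 2,4-dichlorophenyl, giving a 2.2-fold lower number from compound 1 to compound 3 (0.34 log units; beyond the scatter) in this series. No available evidence explains either result. Still open, as far as these compounds go, is whether an amine, a carboxylic acid or a longer alkoxy chain such as butoxy would fit this position equally well.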